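Working notes: from compound 2 to compound 4

The compounds below may be only part of what the source reports. "The series", "measured", "known", "first", "only" and "open" are said of these compounds alone.

Compound 1 `COc1cc(/C=C/C(=O)c2sc(Nc3ccccc3C)nc2C)cc(OC)c1OC`, in a functional assay on Bel-7402 cells (Homo sapiens) for cytotoxicity, read by MTT assay; on this read-out higher numbers stand for weaker inhibition and lower numbers for stronger inhibition: 10300 nM.
Compound 2 `COc1cccc(/C=C/C(=O)c2sc(Nc3ccc(Cl)c(Cl)c3)nc2C)c1`, in this assay: > 25000 nM, a limit.
Compound 3 `COc1ccc(/C=C/C(=O)c2sc(Nc3ccc(Cl)c(Cl)c3)nc2C)cc1`, in this assay: > 25000 nM, a limit.
Compound 4 `COc1cccc(/C=C/C(=O)c2sc(Nc3cccc(Cl)c3)nc2C)c1`: not yet measured.

Compound 2 stands at the limit of this assay, > 25000 nM, so no number is known for it. Compound 3 also sits at a limit, > 25000 nM. Within the data shown here, since the limit of > 25000 nM in this assay, at which 2 of the 3 values shown sit, covers both, the one step between measured compounds, a step that the two limits leave unreadable from compound 2 to compound 3, cannot be read. Compound 1 differs from compound 2 at two places; in this assay compound 1 gives 10300 nM, which is a number rather than a limit.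

Compound 4 differs from compound 2 by hydrogen in place of chloro on an aromatic carbon. No measured step bears on this change, and the single step shown is unreadable, so no size or direction can be drawn from the data.

With compound 2 at a limit, the expected step of a number no higher from compound 2 to compound 4 (the limit leaves the size open) is set as none beyond the scatter. Compound 4 is therefore estimated at 25000 nM, between 10000 nM and 60000 nM, and is expected most likely to return only a limit again.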

Compound 4, half-maximal inhibitory concentration: > 25000 nM
Compound 4: a limit, no number; the forecaster's own chance of this, stated with the estimate: 60%; the middle value sits exactly at the limit.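

In this assay compound 4 gives > 25000 nM as a limit and not a number. Among these compounds, no step from compound 2 to compound 4 can be read, because both sit at one limit: the limit of > 25000 nM in this assay, at which 3 of the 4 values shown sit.

The compounds shown leave open what hydrogen in place of chloro on an aromatic carbon does to the value.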